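Adding isopropyl to the phenyl of compound 3

A few compounds are considered here, and "the series" means these few. Any claim that something is new, unique, unknown or untested is made for them only; others in the source may bear on it.

compound 1 `CCCCOc1ccnc2c(O)c(CNC(=O)C3CCCCC3)ccc12`: 510 nM
compound 2 `CCCCC(=O)NCc1ccc2cccnc2c1O`: "nd" (no result reported)
compound 3 `CCCC(=O)NC(c1ccccc1)c1cc(Cl)c2cccnc2c1O`: 110 nM

In a functional assay on Daoy cells (Homo sapiens) for antiproliferative activity, read by trypan blue exclusion and crystal violet staining, with a stated time of 72 h (on this read-out higher numbers stand for weaker inhibition and lower numbers for stronger inhibition), compound 3 gives 110 nM, the lower of the two numbers available and beyond the scatter from the other one, while compound 2 has no number. Compound 4 `CCCC(=O)NC(c1ccc(C(C)C)cc1)c1cc(Cl)c2cccnc2c1O` differs from compound 3 at one place: isopropyl in place of hydrogen on an aromatic carbon. Phenyl becomes 4-isopropylphenyl, with isopropyl in place of hydrogen on an aromatic carbon. Within the data shown here, no measured pair shows a change of this kind, so no step beyond the scatter is expected in this assay. The expected step of a 1.2-fold higher number from compound 3 to compound 4 (0.07 log units; within the scatter) is small and carries wide uncertainty. For compound 4 the estimated value is 130 nM (expected range 40 nM to 420 nM).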

Compound 4, half-maximal inhibitory concentration: 90 nM
Compound 4: middle estimate off by 1.4-fold (0.16 log units), on the high side; low and high end bracket the measured number.
By their numbers in this assay, from the lowest: compounds 4 and 3 (each within the scatter of the next); then compound 1.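

In this assay putting isopropyl on the phenyl, at the aromatic carbon para to a large group, gives a 1.2-fold lower number from compound 3 to compound 4 (0.09 log units; within the scatter) and so leaves the number within the scatter. Among the compounds shown, this is the first change at this position, and it shows that the position takes a branched alkyl group with the activity kept.

From the compounds shown here alone, whether an amine, a carboxylic acid or a longer chain at the same carbon would also keep the activity stays open. No evidence is available on what lies behind this result.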